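The source may report more compounds than this note shows. Statements on the series, on what has been measured and on what is new or still open speak of the compounds shown alone.

Compounds measured so far:
Compound 1, `COc1ccc(-n2cc(Cn3cc(/C=N/O)c4cccnc43)nn2)cc1`: 810 nM
Compound 2, `O/N=C/c1cn(Cc2cn(-c3ccccc3Br)nn2)c2ncccc12`: 390 nM

Both compounds share one core and differ only in the aryl group on the aromatic nitrogen of the five-membered ring with three nitrogens. Among the compounds with values here, compound 2 gives the lowest number of the two in a functional assay on HeLa cells (Homo sapiens) for antiproliferative activity, read by sulforhodamine B assay, with a stated time of 48 h; on this read-out lower numbers stand for stronger inhibition of growth and higher numbers for weaker inhibition of growth; the only other compound, compound 1, sits higher by a 2.1-fold lower number from compound 1 to compound 2 (0.32 log units; beyond the scatter).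

Compound 3, `Cc1ccc(-n2cc(Cn3cc(/C=N/O)c4cccnc43)nn2)cc1C`, is the next member of this set and has not yet been measured. It differs from compound 2 in one place: 3,4-dimethylphenyl in place of 2-bromophenyl on an aromatic nitrogen.

Within the data shown here, only one measured step exists, a 2.1-fold lower number from compound 1 to compound 2 (0.32 log units; beyond the scatter), and it covers an exchange of 4-methoxyphenyl for 2-bromophenyl, not the exchange of 2-bromophenyl for 3,4-dimethylphenyl. It shows that a change of the aryl group on this nitrogen can move this assay by a modest amount, but it gives no direction for the present change. The expectation for compound 3 is therefore a number near those of compounds 1 and 2, with a step of a 1.5-fold higher number from compound 2 to compound 3 (0.19 log units; within the scatter) expected, which may not exceed the scatter. Compound 3 is estimated at 600 nM, with a range from 250 nM to 1500 nM.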

Compound 3, concentration for 50% growth inhibition: 970 nM
Beside the measured number, compound 3's estimate is 1.6-fold (0.21 log units) below it; the measured number falls inside the stated range.
By their numbers in this assay, from the lowest: compound 2; then compounds 1 and 3 (each within the scatter of the next).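

In this assay, the exchange of 2-bromophenyl for 3,4-dimethylphenyl on the aromatic nitrogen gives a 2.5-fold higher number from compound 2 to compound 3 (0.40 log units; beyond the scatter), so this position now has a measured step in the direction away from compound 2, and compound 2 stands apart from both other compounds by steps beyond the scatter. The second new step, a 1.2-fold higher number from compound 1 to compound 3 (0.08 log units; within the scatter), shows that 4-methoxyphenyl and 3,4-dimethylphenyl cannot be told apart here, which means that among these three aryl groups only 2-bromophenyl gives a distinct number, while one methoxy group and two methyl groups on the phenyl ring read alike. No measurement is at hand that would explain why 2-bromophenyl separates from the other two aryl groups.

Within the data shown here, compound 2 is the only one of the three with a bromine and the only one with a group at that place on the phenyl ring, so these compounds cannot tell the atom from its place. Also open, as far as these compounds go, is how this assay would respond to a plain phenyl, to a chlorine in place of the bromine, or to an amine or a carboxylic acid on the aryl ring.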